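The compounds below may be only part of what the source reports. "The series", "measured", "known", "first", "only" and "open" are said of these compounds alone.

Series notes. Three compounds carry numbers in a functional assay on DU-145 cells (Homo sapiens) for cytotoxicity, read by trypan blue exclusion, with a stated time of 96 h; a lower number here means a stronger inhibitor, a higher number a weaker inhibitor. Compound 1 `COc1ccc(NS(=O)(=O)/C=C/c2c(F)cc(F)cc2F)cc1` gives 75000 nM. Compound 2 `COc1cc(OC)c(/C=C/S(=O)(=O)Nc2ccc(OC)c(O)c2)c(OC)c1` gives 30 nM, the lowest number of the three, and compound 3 `COc1ccc(NS(=O)(=O)/C=C/c2c(OC)cc(OCCCC(=O)O)cc2OC)cc1O` gives 10000 nM. Compound 2 stands apart: the nearest measured number is that of compound 3, with the step of a 330-fold higher number from compound 2 to compound 3 (2.52 log units; beyond the scatter) beyond the scatter, and compound 1 sits further away still.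

Compound 4 `COc1cc(OC)c(/C=C/S(=O)(=O)Nc2ccc(OC)c(NC(C)(C)C(=O)O)c2)c(OC)c1` has no number yet in this assay. Its change from compound 2 is (1-carboxy-1-methylethyl)amino in place of hydroxy on an aromatic carbon. Among the compounds with values here, one measured step bears on it: a 330-fold higher number from compound 2 to compound 3 (2.52 log units; beyond the scatter), in which 2-carboxyethyl enters in place of hydrogen on a saturated chain carbon bound to an oxygen on an aromatic ring, and the number rises sharply. Within the data shown here, compound 4 likewise gains a group carrying a carboxy, though the group and its place differ, and no measured pair changes the hydroxy of compound 2. Among the measured compounds shown here, the expectation for compound 4 is therefore a large rise in the number, toward compound 3, with wide uncertainty because the step of a 330-fold higher number from compound 2 to compound 3 (2.52 log units; beyond the scatter) is the only guide. The estimated step is a 100-fold higher number from compound 2 to compound 4 (2.00 log units; beyond the scatter). Compound 4 is expected at 3000 nM, with a range from 300 nM to 30000 nM.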

Compound 4, half-maximal inhibitory concentration: 70 nM
The estimate for compound 4 lay 43-fold (1.63 log units) above the measured number, and the stated range ends above it.
By their numbers in this assay, from the lowest: compound 2; then compound 4; then compound 3; then compound 1.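

In this assay, (1-carboxy-1-methylethyl)amino in place of hydroxy on this aromatic carbon, ortho to a methoxy group, gives a 2.3-fold higher number from compound 2 to compound 4 (0.37 log units; beyond the scatter), so this position accepts a group of 7 heavy atoms in place of 1 at only a modest cost. The earlier step, a 330-fold higher number from compound 2 to compound 3 (2.52 log units; beyond the scatter), where 2-carboxyethyl enters on a saturated chain carbon bound to an oxygen on an aromatic ring, is large, so in these two pairs a group carrying a carboxy does not give a step of the same size at both places, although the two groups also differ from each other. Nothing shown here accounts for the difference in size between these two steps.

The compounds shown leave open whether the carboxylic acid or the amine link governs the number at this aromatic carbon, a question that a plain amine or the methyl ester of the same group would help to separate. Also open, going by these compounds, is how the number responds to a longer chain between that nitrogen and the carboxylic acid, or to removal of the two methyl groups.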